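Iodo in place of phenyl on the shared core

The compounds below may be only part of what the source reports. "The series", "measured", "known", "first", "only" and "open" are said of these compounds alone.

Compound 1 `Cc1ncnc2c1c(I)cn2[C@@H]1O[C@H](CO)[C@@H](O)[C@H]1O`: 4720 nM
Compound 2 `COc1ncnc2c1c(-c1ccoc1)cn2[C@@H]1O[C@H](CO)[C@@H](O)[C@H]1O`: 110 nM
Compound 3 `COc1ncnc2c1c(-c1ccccc1)cn2[C@@H]1O[C@H](CO)[C@@H](O)[C@H]1O`: > 20000 nM

In a functional assay on HCT-116 cells (Homo sapiens), read by MTT assay, with a stated time of 72 h (a higher number here means a weaker inhibitor, a lower number a stronger inhibitor), compound 3 reaches only the limit of the assay, > 20000 nM, so its true number is not known (the limit of > 20000 nM in this assay, at which 1 of the 3 values shown sits). Compound 4 `COc1ncnc2c1c(I)cn2[C@@H]1O[C@H](CO)[C@@H](O)[C@H]1O` differs from compound 3 by iodo in place of phenyl on an aromatic carbon. Among the measured compounds shown here, the one measured step that bears on this is an at least 180-fold higher number from compound 2 to compound 3 (2.25 log units; beyond the scatter), a large worsening when phenyl entered; taking phenyl away again is therefore expected to move this assay back down. Compound 1 carries the same iodo with a methyl instead of a methoxy and gives 4720 nM. Compound 4 is therefore estimated at 2500 nM (range 500 nM to 15000 nM), an expected step of an at least 8.0-fold lower number from compound 3 to compound 4 (0.90 log units; beyond the scatter).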

Compound 4, half-maximal inhibitory concentration: > 20000 nM
Compound 4 was reported as a limit; the forecaster's own chance of this, stated with the estimate: 15%; middle value at least 8.0-fold (0.90 log units) away from the limit.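

In this assay, iodo in place of furan-3-yl on this aromatic carbon gives an at least 180-fold higher number from compound 2 to compound 4 (2.25 log units; beyond the scatter), so among the groups shown with the methoxy, only furan-3-yl gives a measured number here. With iodo held on this carbon, methoxy in place of methyl gives an at least 4.2-fold higher number from compound 1 to compound 4 (0.62 log units; beyond the scatter), so the change at that other aromatic carbon also registers in this assay. Compound 3 and compound 4 both stand at a limit, and the step between them cannot be read: the limit of > 20000 nM in this assay, at which 2 of the 4 values shown sit.

Going by these compounds, whether a thiophen-3-yl or an amine on this carbon would keep a measured number remains open. So does the effect of methyl in place of methoxy when furan-3-yl is present.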